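The compounds below may be only part of what the source reports. "The series", "measured", "known", "first", "only" and "open" are said of these compounds alone.

Compound 1 `CCCCCCc1nc(-c2ccc(CNC(=O)[C@H]3NCC[C@@H]3O)cc2)no1` carries a hexyl chain on its five-membered aromatic ring. In a physicochemical assay for solubility, at pH 7.4 (a lower number here means a less soluble compound, a higher number a more soluble compound), compound 1 reaches only a limit, > 50 ug/mL, so no exact number is known for it. Compound 2 `O=C(NCc1ccc(-c2noc(CCC3CCCCC3)n2)cc1)[C@H]1NCC[C@@H]1O` has a 2-cyclohexylethyl group in the same place. In this assay compound 2 gives 26 ug/mL, the only exact number among these two compounds. Among the compounds with values here, the one measured step, an at least 1.9-fold lower number from compound 1 to compound 2 (0.28 log units; that floor lies within the scatter), is the only guide here, and it is small.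

Compound 3 `O=C(NCc1ccc(-c2noc(C3CCCCCC3)n2)cc1)[C@H]1NCC[C@@H]1O` differs from compound 2 by cycloheptyl in place of 2-cyclohexylethyl on an aromatic carbon. The groups that leave and enter are of similar size, and the measured step from a chain to a ring-bearing chain was small, so no step beyond the scatter is expected: a 1.2-fold higher number from compound 2 to compound 3 (0.06 log units; within the scatter). Compound 3 is therefore estimated at 30 ug/mL, between 12 ug/mL and 60 ug/mL.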

Compound 3, solubility: > 50 ug/mL
Compound 3: only a limit was reported (the forecaster's own chance of this, stated with the estimate: 25%); at least 1.6-fold (0.22 log units) between middle value and limit.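

Placing cycloheptyl directly on the aromatic carbon, with no chain in between, gives an at least 1.9-fold higher number from compound 2 to compound 3 (0.28 log units; that floor lies within the scatter) in this assay, so this ring at this position does not bring a lower number than the 2-cyclohexylethyl group. Compound 3 gives only a limit, so this step is a floor: the real step could be larger, but what is shown does not place it beyond the usual scatter. The step from compound 1 to compound 3 cannot be read, because both values are limits: the limit of > 50 ug/mL in this assay, at which 2 of the 3 values shown sit.

Still open, from the compounds shown here alone, is how far compound 3 really lies from compound 2 or compound 1 in this assay. Also open, going by these compounds, is how a smaller ring such as cyclopentyl, an amine or a carboxylic acid would read on the same aromatic carbon.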